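Working notes: from compound 1 toward compound 4

This account rests on a few compounds, and the source may have more. Where it says the series, first, only, none or still open, it means among the compounds named here.

Measured so far:
compound 1 `Cc1ccc(NC(=O)c2cccc(C(F)(F)F)c2)cc1OC1CCN(C(=O)c2cccnc2)CC1` — > 10000 nM
compound 2 `Cc1ccc(NC(=O)c2cccc(C(F)(F)F)c2)cc1OC1CCN(C(=O)c2ccno2)CC1` — > 10000 nM
compound 3 `O=C(Nc1ccc(Cl)c(OC2CCN(C(=O)c3cccnc3)CC2)c1)c1cccc(C(F)(F)F)c1` — > 10000 nM

In an ADME assay on BaF3 cells (Mus musculus) for antiproliferative activity (on this read-out higher numbers stand for weaker inhibition of growth and lower numbers for stronger inhibition of growth), compound 1 gives > 10000 nM, which is a limit of the assay and not a number. The value of compound 2 is likewise a limit. The value of compound 3 is likewise a limit. Accordingly a step that the two limits leave unreadable from compound 1 to compound 2 and a step that the two limits leave unreadable from compound 1 to compound 3 cannot be read, as the limit of > 10000 nM in this assay, at which 3 of the 3 values shown sit, shows. Compound 4 `Cc1ccc(NC(=O)Nc2ccc(Cl)c(C(F)(F)F)c2)cc1OC1CCN(C(=O)c2cccnc2)CC1` differs from compound 1 by (4-chloro-3-(trifluoromethyl)phenyl)amino in place of 3-(trifluoromethyl)phenyl on a carbonyl carbon. Within the data shown here, no measured step bears on this change. With all three values sitting at the limit, compound 4 is expected near that limit, at 10000 nM (range 2000 nM to 30000 nM), which would be a step of a number no higher from compound 1 to compound 4 (the limit leaves the size open) from compound 1.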

Compound 4, concentration for 50% growth inhibition: 3300 nM
For compound 4 the middle estimate is 3.0-fold (0.48 log units) above the measured one, and the stated range covers the measured number.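

In this assay, (4-chloro-3-(trifluoromethyl)phenyl)amino in place of 3-(trifluoromethyl)phenyl on the carbonyl carbon gives an at least 3.0-fold lower number from compound 1 to compound 4 (0.48 log units; beyond the scatter). For compound 1, > 10000 nM is a limit of the assay and not a number. This position is the first shown to bring a value off that limit, which neither earlier change did, and those earlier steps cannot be read: the limit of > 10000 nM in this assay, at which 3 of the 4 values shown sit.

From the compounds shown here alone, the change brings in the chloro and the amino nitrogen together, so the share of each in the step stays open. Also open, going by these compounds, is how a bromo or a methoxy in place of that chloro, or a methyl on that nitrogen, would read.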